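This account rests on a few compounds, and the source may have more. Where it says the series, first, only, none or still open, it means among the compounds named here.

Of the compounds shown here, two with one shared core have been tested in a functional assay on HepG2 cells (Homo sapiens) for antiproliferative activity, read by MTT assay, with a stated time of 72 h; a lower number here means a stronger inhibitor, a higher number a weaker inhibitor: compound 1 `O=C1COc2ccc(-c3cnc4ccccc4c3)cc2N1C1CCCCC1` and compound 2 `Cc1ccc(N2C(=O)COc3ccc(-c4cnc5ccccc5c4)cc32)cc1`. Compound 1 gives > 40000 nM, which is a limit of the assay and not a number. Compound 2 gives > 40000 nM, which is also a limit. All the data so far amount to the limit of > 40000 nM in this assay, at which 2 of the 2 values shown sit, so compound 2 has no readable potency. Among the measured compounds shown here, the only measured step is a step that the two limits leave unreadable from compound 1 to compound 2, and it offers no size to carry forward. Compound 3 `O=C1COc2ccc(-c3cnc4ccccc4c3)cc2N1c1ccc(F)cc1` alters compound 2 in one place: fluoro in place of methyl on an aromatic carbon. With no readable step as a guide, no change beyond the scatter is expected in this assay. The expected size is a number no higher from compound 2 to compound 3 (the limit leaves the size open). The estimate for compound 3 is 40000 nM, with an expected range from 15000 nM to 80000 nM.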

Compound 3, half-maximal inhibitory concentration: 37200 nM
Compound 3: middle estimate off by 1.1-fold (0.03 log units), on the high side; low and high end bracket the measured number.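

In this assay, among the compounds shown here, compound 3 gives 37200 nM, the only readable number among the three compounds, so a 4-fluorophenyl group on this amide-type nitrogen allows a potency to be read, though a very weak one. Placing fluoro in place of methyl on the aromatic carbon gives an at least 1.0-fold lower number from compound 2 to compound 3 (0.03 log units; that floor lies within the scatter), while 4-fluorophenyl in place of cyclohexyl gives an at least 1.0-fold lower number from compound 1 to compound 3 (0.03 log units; that floor lies within the scatter). Both steps are only floors and not true sizes, since the other two values are limits of the assay and not numbers: the limit of > 40000 nM in this assay, at which 2 of the 3 values shown sit.

On these data alone, it stays open whether another group at this same place on the aromatic ring, such as chloro, methoxy or an amine, would give a clearly lower number than compound 3 does. As far as these compounds go, it is equally open whether a carboxylic acid or a longer chain on the amide-type nitrogen would do so.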